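The source may report more compounds than this note shows. Statements on the series, on what has been measured and on what is new or still open speak of the compounds shown alone.

Measured compounds:
- Compound 1, `C=C1CCCC(C)(C)C1CC[C@]1(C)CC[C@@H]([C@@H](C)C(=O)O)OO1`, in a functional assay on CCRF-CEM cells (Homo sapiens) for inhibition (on this read-out higher numbers stand for weaker inhibition of growth and lower numbers for stronger inhibition of growth), gives 2270 nM.
- Compound 2, `C=C1CCCC(C)(C)C1CC[C@]1(C)CC[C@H]([C@@H](C)C(=O)OC)OO1`, in this assay gives 1270 nM.
- Compound 3, `CC1=C(CC/C(C)=C/CC[C@@]2(C)CC[C@@H]([C@H](C)C(=O)O)OO2)C(C)(C)CCC1`, in this assay gives 61700 nM.

Compound 1 stands second highest among these three numbers. Its nearest neighbour is compound 2, whose number is lower but within the usual scatter, so the two cannot be told apart. Compound 3 is furthest away, with a number far higher, beyond the scatter.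

Compound 4, `C=C1CCCC(C)(C)C1CC[C@@]1(C)CC[C@H]([C@@H](C)C(=O)O)OO1`, has not yet been measured. It keeps every atom and bond of compound 1 and differs only in the drawn configuration at two ring carbons: the two compounds have the same atoms and bonds; at least one stereo element is drawn with a configuration in one of them and without one in the other: 2 of 4 stereo elements differ; a stereocentre at a saturated ring carbon is drawn R in compound 1 and S in compound 4; a stereocentre at a saturated ring carbon is drawn S in compound 1 and R in compound 4.

Within the data shown here, no step between two measured compounds that differ in one place is available, so the size of this change has to be guessed. The weaker compound 3 changes the whole core rather than a single stereocentre. Among the measured compounds shown here, no measured step tells how a change of configuration alone acts here. The expectation is a small step, quite possibly none beyond the scatter, in either direction. Compound 4 is therefore estimated at 3000 nM, with a range of 800 nM to 12000 nM, meaning an expected step of a 1.3-fold higher number from compound 1 to compound 4 (0.12 log units; within the scatter).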

Compound 4, concentration for 50% growth inhibition: 1760 nM
Compound 4: middle estimate off by 1.7-fold (0.23 log units), on the high side, and the stated range covers the measured number.
By their numbers in this assay, from the lowest: compounds 2, 4 and 1 (each within the scatter of the next); then compound 3.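

In this assay, changing the drawn configuration at two saturated ring carbons gives a 1.3-fold lower number from compound 1 to compound 4 (0.11 log units; within the scatter), so the two compounds cannot be told apart. Among these compounds, this is the first step that isolates configuration, with every atom and bond unchanged, and for this pair the change at these two carbons leaves the growth read-out within the usual scatter. The structures add one further point about the place where the two compounds differ, which offers a caution about how firmly the configurations can be compared: the fact that one of compounds 1 and 4 is drawn with a defined configuration and the other without, at the place where they differ.

Going by these compounds, both carbons change together, so the effect of changing only one of them remains open, and two separate effects could cancel within this pair. Also open, on these data alone, is how an amide or a primary alcohol in place of the carboxylic acid of compound 4 would read.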